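The source may hold more compounds than are shown below. What is called first, only, known or untested is meant among the compounds shown, and "the series" means these compounds.

Measured compounds and their values:
compound 1, `Cc1cc(O)c(C2=NN(c3ccc(S(N)(=O)=O)cc3)C(c3ccccc3O)C2)cc1Cl`: 40700 nM
compound 2, `Cc1cc(O)c(C2=NN(c3ccc(S(N)(=O)=O)cc3)C(/C=C/c3ccccc3)C2)cc1Cl`: 15200 nM
compound 3, `COc1ccc(C2CC(c3cc(Cl)c(C)cc3O)=NN2c2ccc(S(N)(=O)=O)cc2)cc1OC`: 3300 nM

All three share one core and differ only in the group attached to a saturated ring carbon. In a functional assay on UO-31 cells (Homo sapiens) for antiproliferative activity, with a stated time of 48 h (a higher number here means a weaker inhibitor of growth, a lower number a stronger inhibitor of growth), compound 3 gives the lowest number of the three: the step of a 12-fold lower number from compound 1 to compound 3 (1.09 log units; beyond the scatter) is large, and the step of a 4.6-fold lower number from compound 2 to compound 3 (0.66 log units; beyond the scatter) is modest, both beyond the scatter.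

Compound 4, `COc1ccc(C2CC(c3cc(Cl)c(C)cc3O)=NN2c2ccc(S(N)(=O)=O)cc2)c(OC)c1OC`, has not been measured. It differs from compound 3 in one place: methoxy in place of hydrogen on an aromatic carbon, so that the 3,4-dimethoxyphenyl of compound 3 becomes 2,3,4-trimethoxyphenyl. Going by the values given here, none of the measured steps adds a methoxy group to a ring that already carries methoxy groups; the steps that come closest, a 12-fold lower number from compound 1 to compound 3 (1.09 log units; beyond the scatter) and a 4.6-fold lower number from compound 2 to compound 3 (0.66 log units; beyond the scatter), exchange the whole aryl group and only show that the aryl group at this position matters. A smaller change is therefore expected here, and a step in this assay that may not exceed the scatter. Compound 4 is estimated at 2500 nM, within a range from 800 nM to 8000 nM. That estimate corresponds to an expected step of a 1.3-fold lower number from compound 3 to compound 4 (0.12 log units; within the scatter).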

Compound 4, concentration for 50% growth inhibition: 2190 nM
For compound 4 the middle estimate is 1.1-fold (0.06 log units) above the measured one; low and high end bracket the measured number.
By their numbers in this assay, from the lowest: compounds 4 and 3 (each within the scatter of the next); then compound 2; then compound 1.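

In this assay, adding a methoxy group to the aryl ring of compound 3 gives a 1.5-fold lower number from compound 3 to compound 4 (0.18 log units; within the scatter), so this carbon, ortho to a large group and ortho to a methoxy group, takes the extra methoxy group without a change that can be told from the scatter. The earlier compounds shown here showed only that exchanging the whole aryl group matters; the 2,3,4-trimethoxyphenyl group keeps the same distance from the other two groups, with a 6.9-fold lower number from compound 2 to compound 4 (0.84 log units; beyond the scatter) and a 19-fold lower number from compound 1 to compound 4 (1.27 log units; beyond the scatter). Nothing shown explains why the added group makes so little difference.

Going by these compounds, it remains open whether this aromatic carbon would accept something other than methoxy just as readily, such as an amine, a carboxylic acid or a longer chain like ethoxy. The three-methoxy result also says nothing about methoxy groups placed elsewhere on this ring.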